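Adding a second methoxy to compound 3

The source may report more compounds than this note shows. Statements on the series, on what has been measured and on what is new or still open speak of the compounds shown alone.

Values in a functional assay on MDA-MB-231 cells (Homo sapiens), read by microscopy and transwell migration, with a stated time of 24 h; a lower number here means a stronger inhibitor, a higher number a weaker inhibitor:
- compound 1 `COc1ccc(C(=O)Nc2nc(-c3cc(OC)c(OC)c(OC)c3)cs2)cc1OC` gives > 25000 nM (a limit)
- compound 2 `COc1cc(-c2csc(N(C)C(=O)c3ccccc3)n2)cc(OC)c1OC` gives 10000 nM
- compound 3 `COc1ccc(C(=O)N(C)c2nc(-c3cc(OC)c(OC)c(OC)c3)cs2)cc1` gives 312 nM

Among the compounds with values here, the entry for compound 1 is a limit and not a number, and it yields no measured step. Within the data shown here, of the two true numbers in this assay, compound 3 holds the lower one at 312 nM and lies well clear of its only measured neighbour, with a 32-fold lower number from compound 2 to compound 3 (1.51 log units; beyond the scatter) separating the two.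

Compound 4 `COc1ccc(C(=O)N(C)c2nc(-c3cc(OC)c(OC)c(OC)c3)cs2)cc1OC` comes from compound 3 by one change: methoxy in place of hydrogen on an aromatic carbon. In words, 4-methoxyphenyl becomes 3,4-dimethoxyphenyl.

One measured step is of the same kind, methoxy in place of hydrogen on an aromatic carbon: a 32-fold lower number from compound 2 to compound 3 (1.51 log units; beyond the scatter). That step was large, but it is a single example. The group changing there carried no methoxy, whereas in compound 3 it already carries one. Neither its size nor its direction can simply be carried over, so no repeat of that gain is expected, and the best guess is no step beyond the scatter, with the range left open on both sides.

The estimated change is a 1.3-fold higher number from compound 3 to compound 4 (0.11 log units; within the scatter) in this series. For compound 4 the expected value is 400 nM in this assay, with 80 nM to 2500 nM as the estimated range.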

Compound 4, half-maximal inhibitory concentration: > 25000 nM
Compound 4: only a limit was reported (the forecaster's own chance of this, stated with the estimate: 8%); middle value at least 62-fold (1.79 log units) from the limit.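

In this assay, methoxy in place of hydrogen at the position ortho to a methoxy group reverses the direction seen for the earlier methoxy step: an at least 80-fold higher number from compound 3 to compound 4 (1.90 log units; beyond the scatter), against a 32-fold lower number from compound 2 to compound 3 (1.51 log units; beyond the scatter). The 3,4-dimethoxyphenyl group also falls short of plain phenyl, with an at least 2.5-fold higher number from compound 2 to compound 4 (0.39 log units; beyond the scatter), so among these three amides the response does not rise with the number of methoxy groups, and compound 3, with the 4-methoxyphenyl group, gives the lowest number of the three at 312 nM. Compound 4 gives a limit and not a number, > 25000 nM, so both readable steps to it are minimum sizes, and the step between the two limit entries cannot be read: the limit of > 25000 nM in this assay, at which 2 of the 4 values shown sit.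

Open, going by these compounds, is whether the loss belongs to methoxy itself or to any group at this place, which a hydroxy, a fluorine or a methyl there in place of methoxy would help to separate. Also open, on these data alone, is how an amine or a carboxylic acid at this place would read in this assay, and what a 3-methoxyphenyl group alone would give.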